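From a Phenoxy to a Sulfanyl Group on the Shared Core

The compounds below may be only part of what the source reports. "The series", "measured", "known", "first", "only" and "open" are said of these compounds alone.

Of the compounds shown here, three have been tested in a functional assay on the whole organism (strain Swiss albino) for inhibition, with Mus musculus as the target, with a stated time of 4 h, at a dose of 70 mg/kg by the oral route; a lower number here means less inhibition, a higher number more inhibition at the dose given (going by the name of the read-out). Compound 1 `Clc1ccc2nc(Nc3nnc(-c4ccccc4)o3)sc2c1` gives 61.1%, compound 2 `Clc1ccc(-c2nnc(Nc3nc4ccc(Cl)cc4s3)o2)c(Cl)c1` gives 79%, and compound 3 `Clc1ccc2nc(Nc3nnc(Oc4ccccc4)o3)sc2c1` gives 52%. Compound 3 stands lowest of the three, though only one of its gaps is beyond the scatter: a number 9.1 percentage points lower from compound 1 to compound 3 (within the scatter), whereas a number 27 percentage points lower from compound 2 to compound 3 (beyond the scatter).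

Compound 4 `Sc1nnc(Nc2nc3ccc(Cl)cc3s2)o1` has not yet been measured. Its change from compound 3 is sulfanyl in place of phenoxy on an aromatic carbon. The two measured steps that bear on it both alter the group at this same place, and both end at compound 3: a number 9.1 percentage points lower from compound 1 to compound 3 (within the scatter) and a number 27 percentage points lower from compound 2 to compound 3 (beyond the scatter). Within the data shown here, neither step carries a sulfanyl group, and no measured compound lacks an aromatic ring at this place, so the expectation rests on a thin base. Removing the ring altogether is expected to lower inhibition, with a number 12 percentage points lower from compound 3 to compound 4 (beyond the scatter). Compound 4 is therefore expected to give 40%, within the range 20% to 60%.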

Compound 4, a percentage reported as inhibition, in the whole organism at one dose (the size of the read-out at that dose, not a potency): 72.3%
For compound 4 the middle estimate is 32.3 percentage points below the measured one; measured number outside the range, above it.
By their numbers in this assay, from the lowest: compounds 3 and 1 (each within the scatter of the next); then compounds 4 and 2 (each within the scatter of the next).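

The sulfanyl group has no ring, yet in this assay it gives a higher number than either group with a single unsubstituted benzene ring: a number 20.3 percentage points higher from compound 3 to compound 4 (beyond the scatter) and a number 11.2 percentage points higher from compound 1 to compound 4 (beyond the scatter). Against the 2,4-dichlorophenyl group, the change gives a number 6.7 percentage points lower from compound 2 to compound 4 (within the scatter), so an aromatic ring at this place is not required for a high number among these compounds, and a single sulfur atom can stand in for the largest group shown. No measurement here explains why this replacement behaves as it does.

From the compounds shown here alone, it remains open whether sulfur itself matters or whether another one-atom group, such as an amine or a hydroxyl, would serve as well. A longer chain attached through the sulfur, such as a methylsulfanyl or benzylsulfanyl group, would show how much more this place accepts.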